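From 4-fluorobenzyl to 3-chlorobenzyl in a cell assay

The source may hold more compounds than are shown below. What is called first, only, known or untested is meant among the compounds shown, and "the series" means these compounds.

In a functional assay on MCF7 cells (Homo sapiens) for cytotoxicity, read by MTT assay, with a stated time of 24 h (a higher number here means a weaker inhibitor, a lower number a stronger inhibitor), compound 1 (`COc1ccc(/C=C2\CN(C(=S)SCc3cn(Cc4ccccc4F)nn3)C/C(=C\c3ccc(OC)cc3)C2=O)cc1`) gives 79400 nM. Compound 2 (`Cc1ccc(/C=C2\CN(Cc3cn(Cc4ccc(F)cc4)nn3)C/C(=C\c3ccc(C)cc3)C2=O)cc1`) gives 29000 nM, the lower of the two numbers and so the stronger result, with a gap beyond the usual scatter. These two compounds differ in more than one place, so their gap cannot be pinned on any single group. Compound 3 (`Cc1ccc(/C=C2\CN(Cc3cn(Cc4cccc(Cl)c4)nn3)C/C(=C\c3ccc(C)cc3)C2=O)cc1`) keeps the core of compound 2 and changes one group: 3-chlorophenyl in place of 4-fluorophenyl on a saturated chain carbon bound to an aromatic nitrogen. Here, 3-chlorophenyl stands in place of 4-fluorophenyl on a saturated chain carbon bound to an aromatic nitrogen. Among the measured compounds shown here, no measured pair shows what such a swap does, so no step beyond the scatter is expected in this assay, and no clear direction. The expected step is a 1.1-fold lower number from compound 2 to compound 3 (0.05 log units; within the scatter). For compound 3 the estimated value is 26000 nM, with a range of 11000 nM to 60000 nM.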

Compound 3, half-maximal inhibitory concentration: 10000 nM
Compound 3: the middle estimate sits 2.6-fold (0.41 log units) above what was measured, and the stated range ends above it.
By their numbers in this assay, from the lowest: compound 3; then compound 2; then compound 1.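

Among the compounds shown here, compound 2 and compound 3 differ in one place only, so this pair gives the first clean reading of this position: in this assay, replacing 4-fluorobenzyl with 3-chlorobenzyl gives a 2.9-fold lower number from compound 2 to compound 3 (0.46 log units; beyond the scatter) and shows that the number responds to a change at this site. The step is modest, yet it arises although both groups count the same heavy atoms and neither has a hydrogen-bond donor or acceptor. No measurement at hand accounts for the step.

The halogen and its place on the ring change together here, so the compounds shown leave open which of the two carries the step; 4-chlorobenzyl and 3-fluorobenzyl groups would separate them. A 3-methylbenzyl group would show whether a halogen is needed at this site at all.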